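The source may report more compounds than this note shows. Statements on the series, on what has been measured and on what is new or still open speak of the compounds shown alone.

Compound 2 `Cc1cccc(N2CC(c3nc(-c4cccc(Cl)c4)no3)CC2=O)c1` is measured in an in vitro functional assay on HEK293-A cells for negative allosteric modulation of metabotropic glutamate receptor 5 (Homo sapiens), read by FLIPR and calcium flux (a lower number here means a stronger inhibitor, a higher number a weaker inhibitor), at 2300 nM. Of the two numbers shown it is the higher, with compound 3 `O=c1oc2ccccc2n1Cc1nc(-c2cccc(Cl)c2)no1` nearest: in this assay compound 3 gives 2100 nM, and the gap between the two lies within the scatter, so neither is set above the other. Compound 1 `O=C1CC(c2nc(-c3cccc(Cl)c3)no2)CN1c1ccc(Cl)cc1` gives in this assay only a limit, > 10000 nM. Among the compounds with values here, the single measured step concerns the aryl group on the amide-type nitrogen in the ring: an at least 4.3-fold lower number from compound 1 to compound 2 (0.63 log units; beyond the scatter), a step beyond the scatter, and one bounded by the limit of > 10000 nM in this assay, at which 1 of the 3 values shown sits.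

Compound 4 `COc1cccc(N2CC(c3nc(-c4cccc(Cl)c4)no3)CC2=O)c1` differs from compound 2 in one place: methoxy in place of methyl on an aromatic carbon. Within the data shown here, no measured step exchanges a methyl for a methoxy, so the only guide is that the aryl group on that nitrogen has moved the number once, by at least a modest amount. On that thin guide the step from compound 2 to compound 4 is expected to be a 1.2-fold lower number from compound 2 to compound 4 (0.06 log units; within the scatter), with no direction claimed beyond the scatter. Compound 4 is therefore estimated at 2000 nM in this assay, expected to fall between 700 nM and 6000 nM.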

Compound 4, half-maximal inhibitory concentration: 690 nM
Compound 4: middle estimate off by 2.9-fold (0.46 log units), on the high side, and the stated range ends above it.
By their numbers in this assay, from the lowest: compound 4; then compounds 3 and 2 (each within the scatter of the next). At a limit, above all of these: compound 1.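

On the aryl group carried by the amide-type nitrogen in the ring, the substituent now matters with its place held fixed, whereas the earlier step changed both the substituent and its place: in this assay, 3-methoxyphenyl in place of 3-methylphenyl gives a 3.3-fold lower number from compound 2 to compound 4 (0.52 log units; beyond the scatter), a step that rests on this one exchange alone. The change adds one oxygen and one hydrogen-bond acceptor by count, but the compounds shown do not separate these from the larger size of the group as the source of the step. Against the 4-chlorophenyl group, 3-methoxyphenyl gives an at least 14-fold lower number from compound 1 to compound 4 (1.16 log units; beyond the scatter), and this step is a bound rather than a measured size: the limit of > 10000 nM in this assay, at which 1 of the 4 values shown sits.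

From the compounds shown here alone, it stays open how methoxy would read elsewhere on that aromatic ring, and whether a longer chain such as ethoxy, a hydroxyl or an amine would read like methoxy in this place. Going by these compounds, the chlorine-bearing aryl group of the shared core is also the same in compounds 1, 2 and 4, so its part in these numbers remains open.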